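Thiourea to cyanoguanidine on the shared core

A few compounds are considered here, and "the series" means these few. Any claim that something is new, unique, unknown or untested is made for them only; others in the source may bear on it.

Compound 2 `C/N=C(\S)NCCCCCCn1nc(-c2ccccc2)ccc1=O` gives 22.2% in a functional assay on the whole organism with Rattus norvegicus as the target, at a dose of 100 mg/kg (on this read-out lower numbers stand for less inhibition and higher numbers for more inhibition at the one dose given (going by the name of the read-out)), the higher of the two numbers shown, though compound 1 `C/N=C(\S)N(C)CCCCn1nc(-c2ccccc2)ccc1=O` gives 17.5%, and a number 4.7 percentage points higher from compound 1 to compound 2 (within the scatter). Compound 3 `C/N=C(\NC#N)NCCCCn1nc(-c2ccccc2)ccc1=O` differs from compound 2 by a group of 7 heavy atoms (3 carbon, 4 nitrogen; no ring) in place of a group of 7 heavy atoms (4 carbon, 2 nitrogen, 1 sulfur; no ring), on a saturated chain carbon, four bonds along the chain from an aromatic nitrogen. Among the measured compounds shown here, no measured step exchanges one of these groups for the other, so the single step from compound 1 to compound 2 is the only guide and it stays within the scatter. Compound 3 is therefore expected to show a number 2.2 percentage points lower from compound 2 to compound 3 (within the scatter), with an estimate of 20% within 5% to 40%.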

Compound 3, a percentage reported as inhibition, in the whole organism at one dose (the size of the read-out at that dose, not a potency): 79%
The estimate for compound 3 lay 59 percentage points below the measured number; the measured number lies above the stated range.
By their numbers in this assay, from the lowest: compounds 1 and 2 (each within the scatter of the next); then compound 3.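

At this saturated chain carbon, four bonds along the chain from an aromatic nitrogen, the earlier pair gave no sign that the end group could matter so much in this assay, yet the cyanoguanidine in place of the thiourea gives a number 56.8 percentage points higher from compound 2 to compound 3 (beyond the scatter) and the same holds against the other thiourea, with a number 61.5 percentage points higher from compound 1 to compound 3 (beyond the scatter). Among these compounds the large gain goes only with the cyanoguanidine. Nothing available explains this gain.

From the compounds shown here alone, whether a urea or a plain amine at this place would keep the gain remains open. So does whether a longer chain would keep it with the cyanoguanidine, and a single dose gives no potency.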